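Adding a methoxymethyl arm to compound 2's methoxy group

The source may hold more compounds than are shown below. What is called first, only, known or untested is meant among the compounds shown, and "the series" means these compounds.

Measured compounds:
compound 1 `C=CC(=O)Nc1cc(Nc2ncnc(Nc3ccc(C(=O)N4CCCCC4)cc3)n2)ccc1C` gives 48500 nM
compound 2 `C=CC(=O)Nc1cccc(Nc2ncnc(Nc3ccc(OC)cc3)n2)c1` gives 90000 nM
compound 3 `C/C=C/C(=O)Nc1cccc(Nc2ncnc(Nc3ccc(C(=O)N4CCCCC4)cc3)n2)c1` gives 13200 nM

All three were tested in a functional assay on Ramos cells (Homo sapiens) for antiproliferative activity, read by CCK-8 assay, with a stated time of 24 h; on this read-out lower numbers stand for stronger inhibition and higher numbers for weaker inhibition. Compound 2 holds the highest number of the three. Its gap to compound 1 lies within the scatter of the method, so the two cannot be told apart; its gap to compound 3 lies beyond the scatter, and compound 3 gives the lower number in this assay.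

Compound 4 `C=CC(=O)Nc1cccc(Nc2ncnc(Nc3ccc(OCCOC)cc3)n2)c1` has not yet been measured. It differs from compound 2 in one place: methoxymethyl in place of hydrogen on a saturated chain carbon bound to an oxygen on an aromatic ring. The rest of the shared core is unchanged. Within the data shown here, no measured pair in this set carries the same change, so there is no direct precedent for its effect in this assay.

With nothing in the set to point either way, the expected step from compound 2 to compound 4 is small, a 1.2-fold lower number from compound 2 to compound 4 (0.08 log units; within the scatter), and not beyond the scatter. Compound 4 is therefore estimated at 75000 nM in this assay, with a range from 25000 nM to 220000 nM, because compound 2 gives 90000 nM and the change is a modest one at the edge of the molecule.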

Compound 4, half-maximal inhibitory concentration: 181000 nM
Estimate against measurement, compound 4: 2.4-fold (0.38 log units) below, and the stated range covers the measured number.
By their numbers in this assay, from the lowest: compound 3; then compounds 1, 2 and 4 (each within the scatter of the next, the first and the last beyond it).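

Extending the methoxy group to 2-methoxyethoxy provides the first step in this set between two compounds that differ in one place. In this assay this change gives a 2.0-fold higher number from compound 2 to compound 4 (0.30 log units; within the scatter) and so compound 2 and compound 4 cannot be told apart by this measurement. At this saturated chain carbon bound to an oxygen on an aromatic ring, the methoxymethyl arm, with its 3 heavy atoms and one hydrogen-bond acceptor, therefore brings no change that the method can resolve and no sign of a gain, while no independent measurement on hand helps to explain this result.

A single pair cannot show whether the chain end matters in general, and an amine such as dimethylamino, a carboxylic acid or a longer chain carrying further ether oxygens could read quite differently here. Among these compounds, it also remains open whether the same arm would behave in the same way on a compound that differs elsewhere in the molecule, as no second pair carries this change.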